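A hydroxymethyl for a neopentyl in a cyclopentyl-urea series

A few compounds are considered here, and "the series" means these few. Any claim that something is new, unique, unknown or untested is made for them only; others in the source may bear on it.

Three ureas built on the same core have been measured in an assay on microsomes for inhibition of acyl-CoA:cholesterol acyltransferase (Oryctolagus cuniculus); on this read-out lower numbers stand for stronger inhibition and higher numbers for weaker inhibition. Compound 1 `Cc1ccccc1C1(CNC(=O)Nc2c(C(C)C)cccc2C(C)C)CCCC1` gives 17 nM in this assay, and compound 3 `CC(C)c1cccc(C(C)C)c1NC(=O)NCC1(c2ccc(F)cc2)CCCC1` gives 23 nM; the two stand within the scatter of each other. Compound 2 `CC(C)c1cccc(C(C)C)c1NC(=O)NCC1(c2ccc(CC(C)(C)C)cc2)CCCC1` gives 159 nM and holds the highest number of the three: a 9.4-fold higher number from compound 1 to compound 2 (0.97 log units; beyond the scatter), and a 6.9-fold lower number from compound 2 to compound 3 (0.84 log units; beyond the scatter). Compound 4 `CC(C)c1cccc(C(C)C)c1NC(=O)NCC1(c2cccc(CO)c2)CCCC1` has not yet been measured. It differs from compound 2 in one place: 3-(hydroxymethyl)phenyl in place of 4-neopentylphenyl on a saturated ring carbon. Both steps that reach compound 2 bear on this change, since each replaces the neopentyl-bearing ring with a smaller substituted phenyl and each moves the number by well over the scatter. The entering group is smaller than the one it replaces, though it carries a hydroxyl and sits at a different ring position, so the comparison is indirect. Compound 4 is therefore expected to give a lower number than compound 2, estimated at 40 nM within 12 nM to 130 nM, a step of a 4.0-fold lower number from compound 2 to compound 4 (0.60 log units; beyond the scatter) that is expected to fall short of the two measured ones.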

Compound 4, half-maximal inhibitory concentration: 15 nM
Compound 4: the middle estimate sits 2.7-fold (0.43 log units) above what was measured, within the range that was stated.
By their numbers in this assay, from the lowest: compounds 4, 1 and 3 (each within the scatter of the next); then compound 2.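

Replacing 4-neopentylphenyl with 3-(hydroxymethyl)phenyl on the saturated ring carbon gives an 11-fold lower number from compound 2 to compound 4 (1.03 log units; beyond the scatter) in this assay, so the move away from the neopentyl-bearing ring also holds for an entering group that carries a hydroxyl and sits at another ring position. The remaining steps, a 1.5-fold lower number from compound 3 to compound 4 (0.19 log units; within the scatter) and a 1.1-fold lower number from compound 1 to compound 4 (0.05 log units; within the scatter), place compound 4 with compounds 1 and 3, leaving only compound 2 apart among the four. Nothing available explains why these numbers fall as they do.

The compounds shown leave open whether the change in compound 4 owes more to losing the neopentyl group or to the ring position, which a 3-neopentylphenyl and a 4-(hydroxymethyl)phenyl group would help separate. They also leave open whether an aminomethyl group or a carboxylic acid would stand with the hydroxymethyl group of compound 4.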